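The source may report more compounds than this note shows. Statements on the series, on what has been measured and on what is new or still open speak of the compounds shown alone.

Of the compounds shown here, two sharing one core have been tested in a functional assay on A549 cells (Homo sapiens) for inhibition, with a stated time of 72 h; on this read-out higher numbers stand for weaker inhibition and lower numbers for stronger inhibition. Compound 1 `CNC(=O)C1=C[C@@H]2[C@@H](C(C)C)CC[C@@](O)(CO)[C@H]2C(=O)OC1` gives > 32000 nM, which is a limit of the assay and not a number. Compound 2 `CC(C)[C@H]1CC[C@@](O)(CO)[C@H]2C(=O)OCC(C(=O)O)=C[C@H]12` gives > 32000 nM, which is likewise a limit and not a number. Compound 2 therefore stands at the limit of > 32000 nM in this assay, at which 2 of the 2 values shown sit. Among the measured compounds shown here, the only measured change, hydroxy in place of methylamino on a carbonyl carbon, is a step that the two limits leave unreadable from compound 1 to compound 2.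

Compound 3 `CC(C)[C@H]1CC[C@@](O)(CI)[C@H]2C(=O)OCC(C(=O)O)=C[C@H]12` differs from compound 2 at a different place: iodo in place of hydroxy on a saturated chain carbon bound to a saturated ring carbon. This is iodo in place of hydroxy on a saturated chain carbon bound to a saturated ring carbon, or hydroxymethyl to iodomethyl. The measured step offers no size to carry over, so only a direction can be expected. Compound 2 gives > 32000 nM, a limit, so any readable number in this assay would mean stronger inhibition. The expected change is an at least 4.0-fold lower number from compound 2 to compound 3 (0.60 log units; beyond the scatter). A limit remains a real possibility for this compound too. Compound 3 is estimated at 8000 nM, with an expected range from 1000 nM to 32000 nM.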

Compound 3, half-maximal inhibitory concentration: 5430 nM
Compound 3: the middle estimate sits 1.5-fold (0.17 log units) above what was measured, within the range that was stated.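

In this assay, among the compounds shown here, replacing hydroxymethyl with iodomethyl produces an at least 5.8-fold lower number from compound 2 to compound 3 (0.77 log units; beyond the scatter), the first change in this set that can be read at all. Compound 2 gives > 32000 nM, which is a limit of the assay and not a number, so the printed step gives a minimum size and no upper bound. The earlier step on the carbonyl carbon cannot be read, which leaves the saturated chain carbon bound to a saturated ring carbon as the only place shown where a change is seen to move the read-out, while most of the set still sits at the limit: the limit of > 32000 nM in this assay, at which 2 of the 3 values shown sit.

Going by these compounds, it remains open whether iodo in particular matters or whether other replacements for hydroxy on that carbon, such as a chloro group, a bromo group or an amine, would also give a readable number. Also open, on these data alone, is what methylamino in place of hydroxy on the carbonyl carbon would do when paired with iodomethyl, since that change can only be measured on a compound with a readable value.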